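The source may report more compounds than this note shows. Statements on the series, on what has been measured and on what is new or still open speak of the compounds shown alone.

Measured in a functional assay on MCF7 cells (Homo sapiens) for cytotoxicity, read by MTT assay, with a stated time of 96 h; on this read-out lower numbers stand for stronger inhibition and higher numbers for weaker inhibition:
- compound 1 `COc1cc(C(=O)c2cn(-c3ccc(N)cc3)cc2-c2ccccc2)cc(OC)c1OC`: 35 nM
- compound 2 `COc1cc(C(=O)c2cn(-c3cccc(N)c3)cc2-c2ccccc2Cl)cc(OC)c1OC`: 40 nM
- compound 3 `COc1cc(C(=O)c2cn(-c3cccc(N)c3)cc2-c2cccc(N)c2)cc(OC)c1OC`: 60 nM

Compound 2 gives 40 nM, and the numbers for compound 1 and compound 3 both lie within the usual scatter of it. Compound 4 `COc1cc(C(=O)c2cn(-c3ccc(N)cc3)cc2-c2ccccc2Cl)cc(OC)c1OC` has the same atoms as compound 2, joined differently: 4-aminophenyl in place of 3-aminophenyl on an aromatic nitrogen. In short, 4-aminophenyl replaces 3-aminophenyl on the aromatic nitrogen.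

Among the compounds with values here, no measured step makes this exact change. Within the data shown here, the only step available is a 1.5-fold higher number from compound 2 to compound 3 (0.18 log units; within the scatter), and it concerns a different group, so it shows only that one replacement elsewhere stayed within the scatter. More direct evidence comes from compound 1, which already carries 4-aminophenyl on its aromatic nitrogen and gives 35 nM. Among the measured compounds shown here, that is a number of the same size as the one for compound 2, although the two also differ in their other aryl group.

In this assay, no change beyond the scatter is therefore expected. The estimated change is a 1.1-fold lower number from compound 2 to compound 4 (0.06 log units; within the scatter). The expected value for compound 4 is 35 nM, with an estimated range of 13 nM to 90 nM.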

Compound 4, half-maximal inhibitory concentration: 83 nM
For compound 4 the middle estimate is 2.4-fold (0.38 log units) below the measured one; the range from low to high includes it.
By their numbers in this assay, from the lowest: compounds 1, 2, 3 and 4 (each within the scatter of the next, the first and the last beyond it).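

In this assay the place of the amino group on the aryl ring attached to the aromatic nitrogen does matter: with the 2-chlorophenyl group kept, moving from 3-aminophenyl to 4-aminophenyl gives a 2.1-fold higher number from compound 2 to compound 4 (0.32 log units; beyond the scatter) and is thus a modest change, yet one that goes beyond the scatter. With 4-aminophenyl in place, the chloro also counts, since adding it gives a 2.4-fold higher number from compound 1 to compound 4 (0.38 log units; beyond the scatter) as a second modest step beyond the scatter, which no earlier step had shown. Nothing measured here explains either step.

As far as these compounds go, it stays open whether moving the amino group has the same effect when a plain phenyl group replaces 2-chlorophenyl. Also open, from the compounds shown here alone, is what happens when a hydroxyl group replaces the amine on that ring, or when a methyl group or a fluorine replaces the chloro.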